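This account rests on a few compounds, and the source may have more. Where it says the series, first, only, none or still open, it means among the compounds named here.

Measured in a functional assay on HCT-116 cells (Homo sapiens) for inhibition, read by MTT assay, with a stated time of 48 h; a lower number here means a stronger inhibitor, a higher number a weaker inhibitor:
Compound 1 `COc1ccc(-n2c(SCC(=O)Nc3ccc(Cl)cc3)nnc2-c2cc(OC)c(OC)c(OC)c2)cc1`: > 60000 nM, a limit and not a number.
Compound 2 `COc1cc(-c2nnc(SCc3ccccc3)n2-c2ccc(N(C)C)cc2)cc(OC)c1OC`: 54000 nM.
Compound 3 `COc1cc(-c2nnc(SCC(=O)c3ccc4ccccc4c3)n2-c2ccc(N(C)C)cc2)cc(OC)c1OC`: 54500 nM.

Going by the values given here, compound 3 stands level with compound 2, the only other compound here with a true number. Compound 4 `COc1cc(-c2nnc(SCC(=O)Nc3ccc(Cl)cc3)n2-c2ccc(N(C)C)cc2)cc(OC)c1OC` departs from compound 3 by one change: (4-chlorophenyl)amino in place of naphthalen-2-yl on a carbonyl carbon. In words, (4-chlorophenyl)amino stands in place of naphthalen-2-yl on a carbonyl carbon. Among the compounds with values here, the one measured step bearing on this is a 1.0-fold higher number from compound 2 to compound 3 (0.00 log units; within the scatter), for (naphthalen-2-yl)carbonyl in place of phenyl on a saturated chain carbon bound to a sulfur. On that single step, nothing beyond the scatter is expected in this assay, and the estimate is a 1.4-fold lower number from compound 3 to compound 4 (0.13 log units; within the scatter). For compound 4 the estimated value is 40000 nM, with an expected range from 12000 nM to 60000 nM.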

Compound 4, half-maximal inhibitory concentration: 39300 nM
Estimate against measurement, compound 4: 1.0-fold (0.01 log units) above; the measured number falls inside the stated range.
By their numbers in this assay, from the lowest: compounds 4, 2 and 3 (each within the scatter of the next). At a limit, above all of these: compound 1.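

In this assay the step is a 1.4-fold lower number from compound 3 to compound 4 (0.14 log units; within the scatter) and shows that the carbonyl carbon can carry (4-chlorophenyl)amino, with its hydrogen-bond donor, in place of naphthalen-2-yl without a change beyond the scatter. The comparison with phenyl agrees, with a 1.4-fold lower number from compound 2 to compound 4 (0.14 log units; within the scatter) for (4-chlorophenyl)carbamoyl in place of phenyl on a saturated chain carbon bound to a sulfur. The step of an at least 1.5-fold lower number from compound 1 to compound 4 (0.18 log units; that floor lies within the scatter) rests on a limit and gives only a floor for dimethylamino in place of methoxy on an aromatic carbon.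

Still open, as far as these compounds go, is whether a morpholine or a carboxylic acid on that carbonyl carbon, or a longer chain on the sulfur, would move the number beyond the scatter.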